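Propargyloxy in Place of Amino on a Benzylamide Chain

The source may report more compounds than this note shows. Statements on the series, on what has been measured and on what is new or still open speak of the compounds shown alone.

Compound 1 `CCC(C)C(N)C(=O)NCc1ccccc1` was examined in a functional assay on the whole organism (strain NMRI) for inhibition, with Mus musculus as the target, in the formalin test, with a stated time of 30 min (a higher number here means that more compound is needed for the effect, a lower number that less compound is needed), and there compound 1 gives only a limit of the assay, > 22 mg/kg. Compound 2 `NCC(N)C(=O)NCc1ccccc1` has no number of its own: in this assay compound 2 gives "not determined" (no result reported), so nothing is recorded for it. Compound 3 `C#CCOCC(N)C(=O)NCc1ccccc1` differs from compound 2 by propargyloxy in place of amino on a saturated chain carbon, two bonds along the chain from an amine nitrogen and a carbonyl carbon. For the measured compounds named here, no step between measured compounds exists here, and the only anchor is the limit of > 22 mg/kg in this assay, at which 1 of the 2 values shown sits. Compound 3 is therefore expected to need a dose near 30 mg/kg, within a range from 10 mg/kg to 90 mg/kg, with a fair chance that again only a limit is reported.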

Compound 3, dose for half-maximal effect: 74 mg/kg
Beside the measured number, compound 3's estimate is 2.5-fold (0.39 log units) below it; low and high end bracket the measured number.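

No step can be read from compound 1 to compound 3: compound 1 carries only a limit of the assay. The compounds shown leave open how propargyloxy in place of amino changes the dose needed, since compound 2 has no result.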